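The source may hold more compounds than are shown below. What is called first, only, known or untested is meant among the compounds shown, and "the series" means these compounds.

Measured so far in a functional assay on MCF7 cells (Homo sapiens) for inhibition, read by MTT assay, with a stated time of 72 h; on this read-out higher numbers stand for weaker inhibition and lower numbers for stronger inhibition:
- Compound 1 `Nc1nc2cc(-c3nn(CCCC(=O)NO)c4ncnc(N)c34)ccc2o1`: > 50000 nM
- Compound 2 `Nc1ncnc2c1c(-c1cnc3[nH]ccc3c1)nn2CCCCC(=O)NO`: > 150000 nM
- Compound 3 `Nc1ncnc2c1c(-c1cnc3[nH]ccc3c1)nn2CCC(=O)NO`: > 150000 nM

Each of these three values is a limit and not a number, so none of the compounds has a measured strength yet. Compound 1 stands at > 50000 nM, which is a limit.

The next compound to be tested is compound 4 `Nc1nc2cc(-c3nn(CCCCCC(=O)NO)c4ncnc(N)c34)ccc2o1`. It keeps the core of compound 1 and extends the chain, so that 5-(hydroxycarbamoyl)pentyl replaces 3-(hydroxycarbamoyl)propyl. Counted at the end of the chain, the change is 2-(hydroxycarbamoyl)ethyl in place of hydroxycarbamoyl on a saturated chain carbon, three bonds along the chain from an aromatic nitrogen.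

Within the data shown here, only one measured step alters a chain: a step that the two limits leave unreadable from compound 2 to compound 3. It shortens the chain, and it offers no size that could be carried over to the longer chain here. The expectation is therefore loose. It rests on the fact that 5-(hydroxycarbamoyl)pentyl has not yet been tried, and the result could again be a limit. The expected change, a rough estimate toward stronger inhibition, is an at least 5.0-fold lower number from compound 1 to compound 4 (0.69 log units; beyond the scatter). For compound 4, the estimated value is 10000 nM, with an expected range from 800 nM to 80000 nM.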

Compound 4, half-maximal inhibitory concentration: 12400 nM
Compound 4: the middle estimate sits 1.2-fold (0.09 log units) below what was measured, within the range that was stated.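

Among these compounds, compound 4 is the first compound here whose result in this assay is a measured number and not a limit, and it shows that the length of this chain matters on the core of compound 1: 5-(hydroxycarbamoyl)pentyl in place of 3-(hydroxycarbamoyl)propyl gives an at least 4.0-fold lower number from compound 1 to compound 4 (0.60 log units; beyond the scatter), a change beyond the usual scatter. From the compounds shown here alone, for compound 1 the value > 50000 nM is a limit and not a number, so this step is a minimum and its true size stays unknown. Even so, adding to the chain at this position brings the core of compound 1 to a value that can be read in this assay, which the shorter chain did not do.

Going by these compounds, the step between compound 2 and compound 3 cannot be read, so it stays open whether 5-(hydroxycarbamoyl)pentyl would bring a similar change on the core those two compounds share. Also open, on these data alone, is what a still longer chain would do on the core of compound 1, or a carboxylic acid or an amine at the chain end in place of hydroxycarbamoyl.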